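Chlorine to Hydroxyl on a Weak Antiproliferative Scaffold

This account rests on a few compounds, and the source may have more. Where it says the series, first, only, none or still open, it means among the compounds named here.

Compound 1 `COc1cc(-n2cnc3ccc(-c4cccc(Cl)c4)cc32)cc(OC)c1OC`: in a functional assay on A549 cells (Homo sapiens) for antiproliferative activity, read by MTT assay, with a stated time of 72 h (on this read-out higher numbers stand for weaker inhibition and lower numbers for stronger inhibition), compound 1 gives 7050 nM.
Compound 2 `COc1cc(-c2ccc3ncn(-c4cc(OC)c(OC)c(OC)c4)c3c2)cc(OC)c1OC`: compound 2 gives > 10000 nM, a limit of the assay.
Compound 3 `COc1cc(-n2cnc3ccc(-c4ccc(Cl)cc4)cc32)cc(OC)c1OC`: compound 3 gives > 10000 nM, also a limit.

Compound 1 is thus the only one of the three with a measured number; the other two sit at the limit of > 10000 nM in this assay, at which 2 of the 3 values shown sit. Going by the values given here, the single step that touches the same position, an at least 1.4-fold higher number from compound 1 to compound 3 (0.15 log units; that floor lies within the scatter), has a floor within the scatter and ends at a limit. Compound 4 `COc1cc(-n2cnc3ccc(-c4ccc(O)cc4)cc32)cc(OC)c1OC` differs from compound 1 by 4-hydroxyphenyl in place of 3-chlorophenyl on an aromatic carbon. Among the compounds with values here, no measured pair exchanges chlorine for hydroxyl, so no direction beyond the scatter can be derived; given an at least 1.4-fold higher number from compound 1 to compound 3 (0.15 log units; that floor lies within the scatter), the move is expected to be a 1.7-fold higher number from compound 1 to compound 4 (0.23 log units; within the scatter), likely toward the limit. Compound 4 is therefore estimated at 12000 nM, within 4000 nM to 40000 nM, with a real chance that only a limit is reported.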

Compound 4, half-maximal inhibitory concentration: 5090 nM
For compound 4 the middle estimate is 2.4-fold (0.37 log units) above the measured one; measured number inside the range.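

In this assay, the 4-hydroxyphenyl group gives a measured number at this position, whereas the 4-chlorophenyl group gives only a limit. Starting from that limit, the exchange of chloro for hydroxy reads as an at least 1.9-fold lower number from compound 3 to compound 4 (0.29 log units; that floor lies within the scatter), so its size stays open. Against the 3-chlorophenyl group, the change reads as a 1.4-fold lower number from compound 1 to compound 4 (0.14 log units; within the scatter), which leaves the two groups unordered, and the values remain close to the top of the range: the limit of > 10000 nM in this assay, at which 2 of the 4 values shown sit. From the compounds shown here alone, whether an amine or a carboxylic acid in place of the hydroxyl would move the number beyond the scatter remains open.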